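A few compounds are considered here, and "the series" means these few. Any claim that something is new, unique, unknown or untested is made for them only; others in the source may bear on it.

Measured so far in a physicochemical assay for solubility, read by nephelometry, measured as kinetic solubility, at pH 2; a lower number here means a less soluble compound, a higher number a more soluble compound:
compound 1 `O=C(Nc1ccc(F)c(C(F)(F)F)c1)Nc1ccccn1`: 1.6 ug/mL
compound 2 `O=C(Nc1cccc(C(=O)O)c1)Nc1ccc(F)c(C(F)(F)F)c1`: 1.6 ug/mL
compound 3 `NC(=O)c1ccccc1NC(=O)Nc1ccc(F)c(C(F)(F)F)c1`: 1.6 ug/mL

Compound 1 stands level with compound 2 and compound 3 at the digits read; its nearest neighbour is compound 2, with no change at those digits, and its furthest is compound 3, also with no change, both within the scatter. Among the measured compounds shown here, no step between two measured compounds that differ in one place is available, so the move to compound 4 `O=C(Nc1cccnc1)Nc1ccc(F)c(C(F)(F)F)c1` rests on the structural change alone: pyridin-3-yl in place of pyridin-2-yl on an amide-type nitrogen. Within this assay the step from compound 1 to compound 4 is expected to remain within the scatter, with no direction favoured, as no change at the digits printed from compound 1 to compound 4 (within the scatter). Compound 4 is accordingly estimated at 1.6 ug/mL in this assay, with a range from 0.8 ug/mL to 4 ug/mL.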

Compound 4, solubility: 50 ug/mL
Compound 4: middle estimate off by 31-fold (1.49 log units), on the low side; measured number above the stated range.
By their numbers in this assay, from the lowest: compounds 1, 2 and 3 (each within the scatter of the next); then compound 4.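

In this assay, the group on the amide-type nitrogen is a sensitive place: pyridin-3-yl in place of pyridin-2-yl gives a 31-fold higher number from compound 1 to compound 4 (1.49 log units; beyond the scatter), although the heavy-atom count stays the same. Among the compounds shown here, this is the first step between compounds that differ in one place, and the first number that stands clear of the others. Nothing available on these compounds accounts for the step.

As far as these compounds go, how pyridin-4-yl, or an amine on the pyridin-3-yl group, would read in this assay remains open. From the compounds shown here alone, whether the step carries over to other cores is also open.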